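The source may report more compounds than this note shows. Statements on the series, on what has been measured and on what is new or still open speak of the compounds shown alone.

Measured so far in a physicochemical assay for acid dissociation:
compound 1 `CC(=O)OCCS(=O)(=O)c1ccc(S(N)(=O)=O)s1` gives 8.65
compound 2 `CC(=O)OCCCS(=O)(=O)c1ccc(S(N)(=O)=O)s1` gives 8.05
compound 3 `CC(=O)OCCCc1ccc(S(N)(=O)=O)cc1` gives 10.2

From compound 1 to compound 2 the change is acetoxymethyl in place of acetoxy on a saturated chain carbon, two bonds along the chain from a sulfonyl sulfur, and it gave a number 0.60 log units lower from compound 1 to compound 2 (beyond the scatter). Compound 4 `CC(=O)OCCCCc1ccc(S(N)(=O)=O)cc1` has not yet been measured; it arises from compound 3 by acetoxymethyl in place of acetoxy on a saturated chain carbon, three bonds along the chain from an aromatic carbon. The cores of compound 1 and compound 3 differ, and that difference is not broken down here. The two changes are the same kind of change but sit in different surroundings: in compound 1 the place is two bonds along the chain from a sulfonyl sulfur, in compound 3 it is three bonds along the chain from an aromatic carbon. Because compound 3 already gives 10.2, the highest of the three, and because the earlier step was a number 0.60 log units lower from compound 1 to compound 2 (beyond the scatter) at a place near the sulfonyl sulfur, a smaller step is expected here, about a number 0.10 log units lower from compound 3 to compound 4 (within the scatter). Compound 4 is therefore estimated at 10.1 in this assay, with a likely range from 9.7 to 10.5.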

Compound 4, acid dissociation constant: 10.5
Estimate against measurement, compound 4: 0.40 log units below, within the range that was stated.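

In this assay the change from acetoxy to acetoxymethyl gave a number 0.60 log units lower from compound 1 to compound 2 (beyond the scatter) on the core of compound 1, whereas on the core of compound 3 it gave a number 0.30 log units higher from compound 3 to compound 4 (within the scatter). The step seen on the first core therefore did not carry over to the second in this single pair, though two pairs cannot set a rule, and the place of the change differs along with the core, so the two cannot be separated. No measurement shown here accounts for the difference.

Still open, on these data alone, is whether 2-acetoxyethyl would follow either step on these cores. Also open, as far as these compounds go, is how an amine or a carboxylic acid in place of the acetoxy would read in this assay.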